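Amide substituent change from compound 2 to compound 3

The source may report more compounds than this note shows. Statements on the series, on what has been measured and on what is new or still open speak of the compounds shown alone.

In a functional assay on PC-3 cells (Homo sapiens) for antiproliferative activity, read by MTT assay, with a stated time of 48 h (on this read-out higher numbers stand for weaker inhibition and lower numbers for stronger inhibition), compound 1 (`CCn1c(C(=O)N(CCC#N)CCC#N)ccc1C(CC)(CC)c1ccc(OCCC(O)(CC)CC)c(C)c1`) reads > 50000 nM, a limit of the assay and not a number. Among the measured compounds shown here, compound 2 (`CCOC(=O)C(CC(=O)OC)NC(=O)c1ccc(C(CC)(CC)c2ccc(OCCC(O)(CC)CC)c(C)c2)n1CC`) gives 5840 nM, the only true number so far. Compound 3 (`CCn1c(C(=O)NC(CC(=O)O)C(=O)OC)ccc1C(CC)(CC)c1ccc(OCCC(O)(CC)CC)c(C)c1`) carries a group of 9 heavy atoms (5 carbon, 4 oxygen; no ring) in place of a group of 11 heavy atoms (7 carbon, 4 oxygen; no ring), on an amide-type nitrogen. For the measured compounds named here, the only measured step, an at least 8.5-fold lower number from compound 1 to compound 2 (0.93 log units; beyond the scatter), shows that this assay responds to changes in this part of the molecule. It offers no direct measure of the new change, but there the smaller group gave the higher number. A higher number is therefore expected, with the estimated step of a 2.4-fold higher number from compound 2 to compound 3 (0.38 log units; beyond the scatter) as the working figure. Compound 3 is expected at 14000 nM (4000 nM to 50000 nM) in this series.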

Compound 3, half-maximal inhibitory concentration: 11200 nM
Compound 3: the middle estimate sits 1.3-fold (0.10 log units) above what was measured; low and high end bracket the measured number.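

In this assay, the exchange on the amide-type nitrogen gives a 1.9-fold higher number from compound 2 to compound 3 (0.28 log units; within the scatter), so the group of 9 heavy atoms and the group of 11 heavy atoms are not told apart here. The new group also retains a measurable reading relative to the nitrile-bearing substituents, with an at least 4.4-fold lower number from compound 1 to compound 3 (0.64 log units; beyond the scatter). Compound 1 reads a limit of the assay and not a number, so that step is only a bound: the limit of > 50000 nM in this assay, at which 1 of the 3 values shown sits.

Open, on these data alone, is how an amine or a longer chain on the amide-type nitrogen would read in this assay.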